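Replacing the methoxyphenyl amide in a calcium-flux series

A few compounds are considered here, and "the series" means these few. Any claim that something is new, unique, unknown or untested is made for them only; others in the source may bear on it.

The compounds here share one core and differ only in the aromatic group carried on the amide nitrogen. Compound 1 `COc1ccc(NC(=O)c2csc(Cc3c(Cl)cccc3Cl)n2)cc1` carries a 4-methoxyphenyl group. In an assay on CHO cells, read by calcium flux (on this read-out higher numbers stand for weaker inhibition and lower numbers for stronger inhibition), compound 1 gives > 4000 nM, which is a limit of the assay rather than a number (the limit of > 4000 nM in this assay, at which 1 of the 3 values shown sits). Compound 2 `O=C(Nc1ccc(C(F)(F)F)cc1)c1csc(Cc2c(Cl)cccc2Cl)n1` gives 140 nM in this assay, and compound 3 `O=C(Nc1ccc(C(F)(F)C(F)(F)F)cc1)c1csc(Cc2c(Cl)cccc2Cl)n1` gives 290 nM. Both measured steps away from compound 1 were large: an at least 28-fold lower number from compound 1 to compound 2 (1.45 log units; beyond the scatter) and an at least 13-fold lower number from compound 1 to compound 3 (1.13 log units; beyond the scatter). Between the two fluorinated compounds the step was modest, a 2.1-fold higher number from compound 2 to compound 3 (0.32 log units; beyond the scatter).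

Compound 4 `O=C(Nc1ccccc1Br)c1csc(Cc2c(Cl)cccc2Cl)n1` is not yet measured. It differs from compound 1 by 2-bromophenyl in place of 4-methoxyphenyl on an amide-type nitrogen. Going by the values given here, the measured steps show only that leaving the 4-methoxyphenyl group for a fluorinated group lowered the number strongly; no measured step places a bromine, and none uses a 2-bromophenyl group, so their bearing on compound 4 is indirect. For compound 4 the expected step is an at least 2.6-fold lower number from compound 1 to compound 4 (0.42 log units; beyond the scatter), smaller than the measured ones though still towards a lower number. Compound 4 is therefore estimated at 1500 nM, within 300 nM to 6000 nM.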

Compound 4, half-maximal inhibitory concentration: > 4000 nM
Compound 4 gave a limit, no number (the forecaster's own chance of this, stated with the estimate: 35%); middle value at least 2.6-fold (0.42 log units) from the limit.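

Compound 1 and compound 4 both stand at a limit of the assay rather than at a number, so no step between them can be read: the limit of > 4000 nM in this assay, at which 2 of the 4 values shown sit.

The compounds shown leave open how 2-bromophenyl and 4-methoxyphenyl compare on the amide nitrogen in this assay.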